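This account rests on a few compounds, and the source may have more. Where it says the series, first, only, none or still open, it means among the compounds named here.

Measured so far in a functional assay on the whole organism (strain C57B/6) with Mus musculus as the target, in the maximal electroshock model; on this read-out higher numbers stand for an effect only at larger amounts of compound and lower numbers for an effect already at smaller amounts:
compound 1 `CCOc1ccc(-n2cnnc2CC)cc1` gives > 100 mg/kg
compound 2 `CCCOc1ccc(-n2cnnc2CC)cc1` gives > 100 mg/kg
compound 3 `CCCCCCOc1ccc(-n2cnnc2CC)cc1` gives 13.2 mg/kg

Within the data shown here, compound 3 is the only member with a read number. The value of compound 1 is a limit of the assay, not a number. The value of compound 2 likewise is a limit. Both steps towards compound 3 are readable: an at least 7.5-fold lower number from compound 1 to compound 3 (0.87 log units; beyond the scatter) and an at least 7.5-fold lower number from compound 2 to compound 3 (0.87 log units; beyond the scatter), each beyond the scatter. The core of compound 3 differs from that of compound 1 by butyl in place of hydrogen on a saturated chain carbon, two bonds along the chain from an oxygen on an aromatic ring.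

The change from compound 1 to compound 2 is methyl in place of hydrogen on a saturated chain carbon, two bonds along the chain from an oxygen on an aromatic ring; its step, a step that the two limits leave unreadable from compound 1 to compound 2, cannot be read, since both values sit at the limit of > 100 mg/kg in this assay, at which 2 of the 3 values shown sit. Compound 4 `CCCCCCCOc1ccc(-n2cnnc2CC)cc1`, not yet measured, differs from compound 3 by methyl in place of hydrogen on a saturated chain carbon, six bonds along the chain from an oxygen on an aromatic ring. This is the same kind of change as from compound 1 to compound 2, but the place differs: two bonds along the chain from the aromatic oxygen in the first pair, six bonds along the chain in the second. The measured pair therefore gives no size to carry over. What remains is that compound 3, the longest chain measured, gives 13.2 mg/kg. The shorter chains of compound 1 and compound 2 give no read number. One further methyl is expected to change little: the step from compound 3 to compound 4 is estimated as a 1.2-fold lower number from compound 3 to compound 4 (0.08 log units; within the scatter). Compound 4 is thus expected to give about 11 mg/kg, within 4 mg/kg to 40 mg/kg.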

Compound 4, dose for half-maximal effect: 8.3 mg/kg
For compound 4 the middle estimate is 1.3-fold (0.12 log units) above the measured one, within the range that was stated.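

In this assay the longer chains give an at least 12-fold lower number from compound 1 to compound 4 (1.08 log units; beyond the scatter) and an at least 12-fold lower number from compound 2 to compound 4 (1.08 log units; beyond the scatter), whereas the last methyl gives a 1.6-fold lower number from compound 3 to compound 4 (0.20 log units; within the scatter). Butyl in place of hydrogen points the same way on the core of compound 1 and on the core of compound 2, although the place along the chain differs, so the direction of this change carries from one core to the other: the same change on two cores in this assay, an at least 7.5-fold lower number (0.87 log units; beyond the scatter) from compound 1 to compound 3 and an at least 12-fold lower number (1.08 log units; beyond the scatter) from compound 2 to compound 4; the limit leaves it open whether they differ. Compound 1 and compound 2 each stand at a limit of the assay, not a number, so neither pair fixes a size that could be carried to a further core: the limit of > 100 mg/kg in this assay, at which 2 of the 4 values shown sit.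

The compounds shown leave open how the number in this assay behaves between the propyl and hexyl chains, and whether it stays level or turns with a longer chain such as octyl or decyl. Also open, from the compounds shown here alone, is whether a chain bearing an amine or a carboxylic acid would keep an effect in the range of compound 4 at 8.3 mg/kg.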